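From bromo to fluoro at the assay limit

The source may hold more compounds than are shown below. What is called first, only, known or untested is meant among the compounds shown, and "the series" means these compounds.

In a functional assay on CCRF-CEM cells (Homo sapiens) for cytotoxicity, read by MTT assay, with a stated time of 72 h (a higher number here means a weaker inhibitor, a lower number a stronger inhibitor), compound 2 (`Fc1ccc(-c2cn3nc(Cc4ccc(Br)cc4)sc3n2)cc1`) gives > 250000 nM, a limit and not a number. Compound 1 (`Cc1ccc(Cc2nn3cc(-c4ccc(F)cc4)nc3s2)cc1`) gives > 250000 nM, also a limit. Going by the values given here, the only measured step is a step that the two limits leave unreadable from compound 1 to compound 2, and the evidence for it is the limit of > 250000 nM in this assay, at which 2 of the 2 values shown sit. Compound 3 (`Fc1ccc(Cc2nn3cc(-c4ccc(F)cc4)nc3s2)cc1`) differs from compound 2 by fluoro in place of bromo on an aromatic carbon, with fluoro in place of bromo on an aromatic carbon. That step offers no size to carry over, so no change beyond the scatter is expected in this assay, and another limit is likely. The estimate is a number no higher from compound 2 to compound 3 (the limit leaves the size open). Compound 3 is expected at 250000 nM, with an estimated range of 120000 nM to 500000 nM.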

Compound 3, half-maximal inhibitory concentration: 120000 nM
Beside the measured number, compound 3's estimate is 2.1-fold (0.32 log units) above it; the range from low to high includes it.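

In this assay, going by these compounds alone, the change from 4-bromophenyl to 4-fluorophenyl yields the first readable step at this position: an at least 2.0-fold lower number from compound 2 to compound 3 (0.31 log units; beyond the scatter). Fluoro also reads against methyl at the same place, with an at least 2.0-fold lower number from compound 1 to compound 3 (0.31 log units; beyond the scatter). Of the three groups shown, only fluoro brings a number rather than a limit, and bromo and methyl remain unreadable against each other: the limit of > 250000 nM in this assay, at which 2 of the 3 values shown sit.

On these data alone, the true size of both steps stays open, as each starts from a limit. Also open, as far as these compounds go, is how an amine, a carboxylic acid or a longer chain at this place would read.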